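This account rests on a few compounds, and the source may have more. Where it says the series, first, only, none or still open, it means among the compounds named here.

In an ADME assay on microsomes from liver (Homo sapiens) for metabolic stability (a lower number here means slower removal, a higher number faster removal of the compound), compound 2 `CCCC(Oc1ccc(-n2cc(C#N)cn2)cc1)c1ccc(C(=O)NCCC(=O)O)cc1` gives < 8 mL/min/kg as a limit of the assay and not a number. Compound 2 therefore stands at the limit of < 8 mL/min/kg in this assay, at which 1 of the 3 values shown sits, and has no exact value. Compound 4 `CCCC(Oc1ccc(-n2cc(Cl)cn2)cc1)c1ccc(C(=O)NCCC(=O)O)cc1` carries chloro in place of cyano on an aromatic carbon and is otherwise the same. Compound 1 `O=C(O)CCNC(=O)c1ccc(C(Oc2ccc(-n3cc(C(F)(F)F)cn3)cc2)C2CCC2)cc1` gives 26 mL/min/kg and compound 3 `O=C(O)CCNC(=O)c1ccc(C(Oc2ccc(-n3cc(C(F)(F)F)cn3)cc2)C2CCCC2)cc1` gives 22 mL/min/kg with trifluoromethyl in that place, but their chains differ from that of compound 2. Within the data shown here, the one measured step of a 1.2-fold lower number from compound 1 to compound 3 (0.07 log units; within the scatter) puts cyclopentyl in place of cyclobutyl and says little about this change. The higher values of compound 1 and compound 3 still point to a modest rise in this assay rather than none. The expected size is an at least 1.3-fold higher number from compound 2 to compound 4 (0.13 log units; that floor lies within the scatter) as a rough estimate. Compound 4 is expected at 11 mL/min/kg within a range of 7 mL/min/kg to 22 mL/min/kg in this estimate.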

Compound 4, clearance: 10 mL/min/kg
Compound 4: the middle estimate sits 1.1-fold (0.04 log units) above what was measured; measured number inside the range.
By their numbers in this assay, from the lowest: compound 4; then compounds 3 and 1 (each within the scatter of the next). At a limit, below all of these: compound 2.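

Compound 2 stands at a limit of the assay and not at a number: the limit of < 8 mL/min/kg in this assay, at which 1 of the 4 values shown sits.

Compound 4 gives 10 mL/min/kg, so this chain now has an exact number in this assay, with chloro in the place of cyano. Read across that limit, the change gives an at least 1.2-fold higher number from compound 2 to compound 4 (0.09 log units; that floor lies within the scatter), so its true size stays unknown and it may be no real change at all.

As far as these compounds go, a methyl or bromo group at this place on the same chain remains open. So does trifluoromethyl there, as compounds 1 and 3 carry it only on other chains.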